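Aryl swap on the saturated ring carbon: compound 4

The source may report more compounds than this note shows. Statements on the series, on what has been measured and on what is new or still open speak of the compounds shown alone.

Measured so far in a functional assay on MCF7 cells (Homo sapiens) for antiproliferative activity, read by MTT assay, with a stated time of 24 h; on this read-out lower numbers stand for stronger inhibition and higher numbers for weaker inhibition:
compound 1 `COc1cc(C2CC(c3ccccc3)=NN2c2ccc(-c3ccccc3)nn2)cc(OC)c1OC`, 70000 nM
compound 2 `Fc1ccc(C2CC(c3ccc(Cl)cc3)=NN2c2ccc(-c3ccccc3)nn2)cc1`, 3750 nM
compound 3 `FC(F)(F)c1ccc(C2CC(c3ccc(Cl)cc3)=NN2c2ccc(-c3ccccc3)nn2)cc1`, 1670 nM

Compound 3 gives the lowest number of the three; compound 2 sits nearest, compound 1 far above it. Compound 4 `COc1cc(C2CC(c3ccc(Cl)cc3)=NN2c2ccc(-c3ccccc3)nn2)cc(OC)c1OC` differs from compound 3 by 3,4,5-trimethoxyphenyl in place of 4-(trifluoromethyl)phenyl on a saturated ring carbon. Among the measured compounds shown here, only one step is available, a 2.2-fold lower number from compound 2 to compound 3 (0.35 log units; beyond the scatter), and it concerns a different exchange on the same aryl, so it bears weakly here. Compound 1 carries the entering 3,4,5-trimethoxyphenyl on that carbon and gives 70000 nM; compound 1 and compound 4 differ in a second place too, so this is a pointer, not a step. A markedly higher number is expected for compound 4, with this assay expected to give 30000 nM (8000 nM to 100000 nM), an estimated 18-fold higher number from compound 3 to compound 4 (1.25 log units; beyond the scatter).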

Compound 4, half-maximal inhibitory concentration: 100000 nM
Compound 4: the middle estimate sits 3.3-fold (0.52 log units) below what was measured; low and high end bracket the measured number.
By their numbers in this assay, from the lowest: compound 3; then compound 2; then compounds 1 and 4 (each within the scatter of the next).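

In this assay, 3,4,5-trimethoxyphenyl on the saturated ring carbon can now be read directly against the two other aryls: a 60-fold higher number from compound 3 to compound 4 (1.78 log units; beyond the scatter), and a 27-fold higher number from compound 2 to compound 4 (1.43 log units; beyond the scatter). Chloro in place of hydrogen on an aromatic carbon changes little with this aryl present, a 1.4-fold higher number from compound 1 to compound 4 (0.15 log units; within the scatter). No available data explain these differences.

As far as these compounds go, whether 4-methoxyphenyl or 4-carboxyphenyl on this carbon would fall nearer compound 3 or compound 4 remains open. Also open, from the compounds shown here alone, is whether chloro matters alongside 4-(trifluoromethyl)phenyl.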